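Pentyl on Selenium: Cytotoxicity of Two Core Pairs

The source may report more compounds than this note shows. Statements on the series, on what has been measured and on what is new or still open speak of the compounds shown alone.

Three compounds were measured in a functional assay on MCF7 cells (Homo sapiens) for cytotoxicity, read by MTT assay, with a stated time of 72 h; on this read-out lower numbers stand for higher toxicity in this test and higher numbers for lower toxicity in this test. Compound 1, `CCCCC[Se]c1nc(NCc2ccccc2)c2ccccc2n1`, gives 99400 nM. Compound 2, `[SeH]c1nc(NCc2ccccc2)c2ccccc2n1`, gives only a limit of the assay, > 100000 nM. Compound 3, `Nc1nc([SeH])nc2ccccc12`, likewise gives only a limit, > 100000 nM.

Compounds 2 and 1 share a core and differ by pentyl in place of hydrogen on a selenium. The step of a number no higher from compound 2 to compound 1 (the limit leaves the size open) cannot be sized, because of the limit of > 100000 nM in this assay, at which 2 of the 3 values shown sit. Compound 3 carries a different core from compound 2; the difference between the two cores is not broken down here, and compound 3 stands only at a limit in this assay.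

Compound 4, `CCCCC[Se]c1nc(N)c2ccccc2n1`, has not been measured. It differs from compound 3 by pentyl in place of hydrogen on a selenium, which is the same change as that from compound 2 to compound 1, with the same surroundings at the selenium. Compound 1 sits at 99400 nM. Compound 2 sits only at a limit of the assay. The measured pair thus gives no sign that the pentyl group moves the cytotoxicity far from where compound 2 stands. Compound 4 is therefore expected to lie near the limit as well, with an expected step that the limit leaves unreadable from compound 3 to compound 4. The estimate for compound 4 in this assay is 110000 nM, between 40000 nM and 400000 nM.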

Compound 4, concentration lethal to 50% of the cells: 90400 nM
Beside the measured number, compound 4's estimate is 1.2-fold (0.09 log units) above it; low and high end bracket the measured number.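

In this assay the pentyl change on the second core gives an at least 1.1-fold lower number from compound 3 to compound 4 (0.04 log units; that floor lies within the scatter), a step that starts from a limit, and the two pentyl compounds show a 1.1-fold lower number from compound 1 to compound 4 (0.04 log units; within the scatter) with hydrogen in place of benzyl on a nitrogen on an aromatic ring. This shows only that, with pentyl on the selenium, the two cores give values within the scatter of each other, and it does not show that the change has the same size on both cores: the same change on two cores in this assay, a number no higher (the limit leaves the size open) from compound 2 to compound 1 and an at least 1.1-fold lower number (0.04 log units; that floor lies within the scatter) from compound 3 to compound 4; the limit leaves it open whether they differ. Compound 2 and compound 3 each stand only at a limit, so neither step has a true size and the transfer of the change from one core to the other remains unmeasured: the limit of > 100000 nM in this assay, at which 2 of the 4 values shown sit.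

The compounds shown leave open whether a shorter chain such as ethyl, or a longer chain such as octyl, on the selenium would give a value clear of the limit in this assay. They also leave open what an amine or a carboxylic acid carried on the chain would do to the number, on either core.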